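The compounds below may be only part of what the source reports. "The series", "measured", "known", "first", "only" and "open" are said of these compounds alone.

Compound 1, `CCCCCc1ccc(-c2cn(C/C=C3\OC(=O)C(OCc4ccccc4)=C3OCc3ccccc3)nn2)cc1`, gives > 100000 nM in a functional assay on CFPAC-1 cells (Homo sapiens) for antiproliferative activity, read by MTT assay, with a stated time of 72 h (on this read-out higher numbers stand for weaker inhibition and lower numbers for stronger inhibition), which is a limit of the assay rather than a number.
Compound 2, `COc1ccccc1-c1cn(C/C=C2\OC(=O)C(OCc3ccccc3)=C2OCc2ccccc2)nn1`, gives > 100000 nM in this assay, likewise a limit of the assay.

The two measured compounds share the same core and differ only in the aromatic group attached to an aromatic carbon. The step between them, a step that the two limits leave unreadable from compound 1 to compound 2, cannot be read, since both values are limits. Among the measured compounds shown here, compound 2 therefore stands at the limit itself, and the only evidence is the limit of > 100000 nM in this assay, at which 2 of the 2 values shown sit.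

Compound 3, `O=C1O/C(=C\Cn2cc(-c3cccc(O)c3)nn2)C(OCc2ccccc2)=C1OCc1ccccc1`, introduces a new change: 3-hydroxyphenyl in place of 2-methoxyphenyl on an aromatic carbon. For the measured compounds named here, no measured step bears on this change, and the single measured step gives neither a size nor a direction. With nothing to point the other way, the most likely outcome is that compound 3 also reaches only the limit, while a readable value is possible.

Compound 3 is therefore estimated to give 100000 nM in this assay, with a range from 30000 nM to 300000 nM. The estimated step is a number no higher from compound 2 to compound 3 (the limit leaves the size open).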

Compound 3, half-maximal inhibitory concentration: 33700 nM
Compound 3: the middle estimate sits 3.0-fold (0.47 log units) above what was measured; the range from low to high includes it.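

With 3-hydroxyphenyl on this aromatic carbon, the series gives its first readable number in this assay: in place of 2-methoxyphenyl, the change is an at least 2.9-fold lower number from compound 2 to compound 3 (0.47 log units; beyond the scatter). In place of 4-pentylphenyl, the change is an at least 2.9-fold lower number from compound 1 to compound 3 (0.47 log units; beyond the scatter). This shows that the group at this position can move the read-out, which the unreadable step between the two earlier compounds could not show, but both new steps start from a limit rather than a number, so their full size stays unknown, and compound 1 and compound 2 remain at that limit of the assay: the limit of > 100000 nM in this assay, at which 2 of the 3 values shown sit.

The compounds shown leave open which part of the change matters, since 3-hydroxyphenyl differs from 2-methoxyphenyl both in carrying a hydroxyl group instead of a methoxy group and in where that group sits on the phenyl ring. They also leave open how the number would respond to other groups on that phenyl ring, such as an amine or a carboxylic acid, or to a plain phenyl ring with no added group at all.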